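The source may report more compounds than this note shows. Statements on the series, on what has been measured and on what is new or still open speak of the compounds shown alone.

Measured in an ADME assay on Raji cells (Homo sapiens) for cytotoxicity, with a stated time of 72 h; a lower number here means that less compound is needed, a higher number that more compound is needed for the effect:
Compound 1 `CSc1ccc(NC(=O)Nc2cc(C)nc3ccccc23)cc1`: > 25000 nM, a limit.
Compound 2 `CCc1ccc(NC(=O)Nc2cc(C)nc3ccccc23)cc1`: > 25000 nM, a limit.
Compound 3 `Cc1cc(NC(=O)Nc2ccc(F)cc2)c2ccccc2n1`: > 25000 nM, a limit.

Compound 3 has only a limit in this assay, so it has no numerical rank within the series. The whole picture so far is the limit of > 25000 nM in this assay, at which 3 of the 3 values shown sit.

The next structure is compound 4 `COC(=O)c1ccc(NC(=O)Nc2cc(C)nc3ccccc23)cc1`, with methoxycarbonyl in place of fluoro on an aromatic carbon, para to a large group: methoxycarbonyl in place of fluoro on an aromatic carbon.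

Three measured steps swap a single group on an aromatic carbon: a step that the two limits leave unreadable from compound 1 to compound 2, a step that the two limits leave unreadable from compound 1 to compound 3 and a step that the two limits leave unreadable from compound 2 to compound 3. Going by the values given here, none has a readable size, yet methylsulfanyl, ethyl and fluoro all leave the compound at the limit, and no measured compound goes against this. Methoxycarbonyl has not been tested, so this precedent is limited. Even so, no step beyond the usual scatter is expected, and the estimated step is a number no higher from compound 3 to compound 4 (the limit leaves the size open).

Compound 4 is estimated at 25000 nM, with an expected range of 10000 nM to 50000 nM.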

Compound 4, half-maximal effective concentration: 17000 nM
Estimate against measurement, compound 4: 1.5-fold (0.17 log units) above; the measured number falls inside the stated range.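

In this assay, going by these compounds alone, methoxycarbonyl on the aromatic carbon para to a large group gives the first number rather than a limit, with compound 4 at 17000 nM. The change reads as an at least 1.4-fold lower number from compound 3 to compound 4 (0.16 log units; that floor lies within the scatter), as an at least 1.4-fold lower number from compound 2 to compound 4 (0.16 log units; that floor lies within the scatter) and as an at least 1.4-fold lower number from compound 1 to compound 4 (0.16 log units; that floor lies within the scatter), so a number has appeared, but no shift beyond the scatter is shown. The steps among compound 1, compound 2 and compound 3 still cannot be read, and the series remains almost entirely at one limit: the limit of > 25000 nM in this assay, at which 3 of the 4 values shown sit.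

Going by these compounds, the true distance between compound 4 and the three compounds at the limit remains open. On these data alone, it is also open whether a carboxylic acid or an amine at this position would give a number, and whether that number would differ from that of compound 4 by more than the scatter.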